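Chloro to methyl on the shared core: working notes

A few compounds are considered here, and "the series" means these few. Any claim that something is new, unique, unknown or untested is made for them only; others in the source may bear on it.

compound 1 `COc1ccc2c(c1)C(=O)CCN2c1nc(Cl)nc2ccccc12` gives 31 nM
compound 2 `COc1ccc2c(c1)CCN2c1nc(Cl)nc2ccccc12` gives 165 nM

Both values come from a functional assay on DU-145 cells (Homo sapiens) for cytotoxicity, read by sulforhodamine B assay; on this read-out higher numbers stand for weaker inhibition of growth and lower numbers for stronger inhibition of growth. Compound 1 gives 31 nM and compound 2 gives 165 nM, so compound 2 holds the higher number of the two, and the gap lies beyond the usual scatter. The next entry is compound 3 `COc1ccc2c(c1)CCN2c1nc(C)nc2ccccc12`, which differs from compound 2 as follows: methyl in place of chloro on an aromatic carbon. This puts methyl in place of chloro on an aromatic carbon, between two ring nitrogen atoms. For the measured compounds named here, no measured pair differs in one place only, so the data give no direct measure of such a step. A small move toward a lower number is expected, possibly none beyond the scatter. The estimate amounts to an expected 2.1-fold lower number from compound 2 to compound 3 (0.31 log units; beyond the scatter). Compound 3 is estimated at 80 nM, with an expected range of 20 nM to 300 nM.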

Compound 3, concentration for 50% growth inhibition: 243 nM
For compound 3 the middle estimate is 3.0-fold (0.48 log units) below the measured one, and the stated range covers the measured number.
By their numbers in this assay, from the lowest: compound 1; then compounds 2 and 3 (each within the scatter of the next).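

For the compounds shown here, the step at this aromatic carbon, between two ring nitrogen atoms, gives the first direct reading of this position: a 1.5-fold higher number from compound 2 to compound 3 (0.17 log units; within the scatter) in this assay. Compound 2 and compound 3 therefore cannot be told apart on this read-out, so for this pair chloro is not required to keep growth inhibition at this level, and methyl serves equally well. No measured property bears on this result, which leaves the finding purely descriptive.

On these data alone, whether an amine, a methoxy group or a longer chain such as propyl at this position would stay level with chloro and methyl remains open. Also open, as far as these compounds go, is whether the same exchange would read the same way on the carbonyl-bearing core of compound 1.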